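Silyl ether analogues of a hydroxycyclopentenone series: cytotoxicity notes

This account rests on a few compounds, and the source may have more. Where it says the series, first, only, none or still open, it means among the compounds named here.

Measured so far:
compound 1 `COc1ccc(C2=C(c3cc(OC)c(OC)c(OC)c3)C(=O)CC2O[SiH2]C(C)(C)C)cc1` — > 100 ug/mL
compound 2 `COc1ccc(C2=C(c3cc(OC)c(OC)c(OC)c3)CC(O)C2=O)cc1[N+](=O)[O-]` — > 100 ug/mL
compound 3 `COc1ccc(C2=C(c3cc(OC)c(OC)c(OC)c3)C(=O)CC2O)cc1` — > 100 ug/mL

In an ADME assay on HEp-2 cells (Homo sapiens) for cytotoxicity, read by MTT assay, with a stated time of 72 h (on this read-out higher numbers stand for weaker inhibition and lower numbers for stronger inhibition), compound 1 gives > 100 ug/mL, which is a limit of the assay and not a number. Compound 2 likewise gives only a limit, > 100 ug/mL. Compound 3 also gives a limit, > 100 ug/mL. The change a group of 5 heavy atoms (4 carbon, 1 silicon; no ring) in place of a hydrogen atom, on an oxygen on a saturated carbon produces a step that the two limits leave unreadable from compound 3 to compound 1; both ends sit at the limit, as the limit of > 100 ug/mL in this assay, at which 3 of the 3 values shown sit, shows. The difference between the cores of compound 2 and compound 3 is not broken down here.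

Compound 4 `COc1ccc(C2=C(c3cc(OC)c(OC)c(OC)c3)CC(O[SiH2]C(C)(C)C)C2=O)cc1[N+](=O)[O-]` is not yet measured. It carries the same change, (a group of 5 heavy atoms (4 carbon, 1 silicon; no ring) in place of a hydrogen atom, on an oxygen on a saturated carbon). The step that the limit leaves unreadable from compound 2 to compound 4 is expected to be unreadable in the same way, because a step that the two limits leave unreadable from compound 3 to compound 1 gave no readable size and the limit of > 100 ug/mL in this assay, at which 3 of the 3 values shown sit, holds every value at the limit. Compound 4 is therefore estimated at 150 ug/mL, most likely reported as a limit again.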

Compound 4, half-maximal inhibitory concentration: > 100 ug/mL
Compound 4 gave a limit, no number (the forecaster's own chance of this, stated with the estimate: 85%); the middle value does not contradict the limit.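

Compound 2 and compound 4 both sit at a limit of the assay, so no step can be read between them: the limit of > 100 ug/mL in this assay, at which 4 of the 4 values shown sit.

From the compounds shown here alone, whether the silicon-bearing group in place of the hydrogen atom changes the read-out at all in this assay stays open.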